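A few compounds are considered here, and "the series" means these few. Any claim that something is new, unique, unknown or untested is made for them only; others in the source may bear on it.

In an assay on cells for agonist activity at Bombesin receptor subtype-3 (Homo sapiens), read by HTRF and inositol phosphate accumulation, with a stated time of 1 h (a higher number here means that more compound is needed for the effect, a lower number that less compound is needed), compound 3 `CC(C)(C)Cc1cnc(CCc2ccc(-c3cccc(F)c3C(=O)O)cc2)n1CCO` gives 3 nM, the lowest of the three numbers measured. Compound 2 `CC(C)(C)Cc1cnc(CCc2ccc(-c3cccc(F)c3C(=O)O)cc2)n1Cc1ccc(C(=O)O)cc1` gives 12 nM, and compound 1 `COC(=O)c1c(F)cccc1-c1ccc(CCc2ncc(CC(C)(C)C)n2CCOc2cccc(O)c2)cc1` gives 13 nM; both of them stand above compound 3 by more than the usual scatter. For the measured compounds named here, the only single-change step measured on this side of the shared core is a 4.0-fold lower number from compound 2 to compound 3 (0.60 log units; beyond the scatter), in which a large aromatic group on the saturated chain carbon bound to the aromatic nitrogen was cut back to a hydroxymethyl and the number fell. Compound 4 `CC(C)(C)Cc1cnc(CCc2ccc(-c3cccc(F)c3C(=O)O)cc2)n1CCOc1cccc(O)c1` moves in the opposite direction: 3-hydroxyphenyl in place of hydrogen on an oxygen on a saturated carbon. Going by the values given here, no measured pair isolates this exact change. Compound 1 carries the same 3-hydroxyphenoxy tail as compound 4, but it has a methyl ester where compound 4 has a carboxylic acid, so it differs from compound 3 in two places and only the two numbers themselves can be set side by side. Given that adding bulk on this chain raised the number in the step of a 4.0-fold lower number from compound 2 to compound 3 (0.60 log units; beyond the scatter) read backwards, compound 4 is expected to land somewhat above compound 3, by a step of about a 2.3-fold higher number from compound 3 to compound 4 (0.37 log units; beyond the scatter). The estimate for compound 4 is therefore 7 nM, with a range from 2.5 nM to 20 nM.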

Compound 4, half-maximal effective concentration: 0.9 nM
For compound 4 the middle estimate is 7.8-fold (0.89 log units) above the measured one; the measured number lies below the stated range.
By their numbers in this assay, from the lowest: compound 4; then compound 3; then compounds 2 and 1 (each within the scatter of the next).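

In this assay the 2-hydroxyethyl chain of compound 3 can be extended to 2-(3-hydroxyphenoxy)ethyl with a 3.3-fold lower number from compound 3 to compound 4 (0.52 log units; beyond the scatter), so a larger group at this position does not by itself raise the number, as the step between compound 2 and compound 3 alone might have suggested. Which group is added matters too: (3-hydroxyphenoxy)methyl in place of 4-carboxyphenyl on the saturated chain carbon bound to an aromatic nitrogen gives a 13-fold lower number from compound 2 to compound 4 (1.12 log units; beyond the scatter), a large step on the same shared core. The new tail also does not act alone, since hydrogen in place of methyl on an oxygen next to a carbonyl group gives a 14-fold lower number from compound 1 to compound 4 (1.16 log units; beyond the scatter), another large step, so with this tail the carboxylic acid reads far lower than its methyl ester.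

Nothing at hand explains why the 3-hydroxyphenoxy tail lowers the number. The compounds shown also leave open whether the hydroxy group on this tail is needed, and how a plain phenoxy, a 3-methoxyphenoxy or a 3-aminophenoxy tail would compare.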